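One More Chain Carbon After Compound 2

This account rests on a few compounds, and the source may have more. Where it says the series, first, only, none or still open, it means among the compounds named here.

- compound 1 `CC1(C)CCc2c(ccc(CNCc3ccccc3)c2O)O1` gives 60000 nM
- compound 2 `CC1(C)CCc2c(ccc(CNCCCc3ccccc3)c2O)O1` gives 27000 nM

Going by the values given here, in a toxicity assay on L6 cells (Rattus norvegicus) for inhibition, read by microscopy and resazurin assay, with a stated time of 70 h (a lower number here means a stronger inhibitor, a higher number a weaker inhibitor), compound 2 holds the lower of the two numbers measured so far, at 27000 nM. Compound 3 `CC1(C)CCc2c(ccc(CNCCCCc3ccccc3)c2O)O1` differs from it as follows: benzyl in place of phenyl on a saturated chain carbon, three bonds along the chain from an amine nitrogen. Among the compounds with values here, the one measured step that bears on this is a 2.2-fold lower number from compound 1 to compound 2 (0.35 log units; beyond the scatter), which also lengthens the chain. Within the data shown here, a further small drop in this assay is therefore expected, no larger than that step and perhaps within the scatter. The expected step is a 1.5-fold lower number from compound 2 to compound 3 (0.18 log units; within the scatter). Compound 3 is estimated at 18000 nM, with an expected range of 8000 nM to 40000 nM.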

Compound 3, half-maximal inhibitory concentration: 15000 nM
Compound 3: middle estimate off by 1.2-fold (0.08 log units), on the high side; measured number inside the range.
By their numbers in this assay, from the lowest: compounds 3 and 2 (each within the scatter of the next); then compound 1.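

In this assay, benzyl in place of phenyl on a saturated chain carbon, three bonds along the chain from an amine nitrogen, gives a 1.8-fold lower number from compound 2 to compound 3 (0.26 log units; within the scatter). The earlier lengthening gave a step beyond the scatter (a 2.2-fold lower number from compound 1 to compound 2 (0.35 log units; beyond the scatter)), whereas this further change cannot be told apart from repeat measurement, so the two values do not establish a continuing trend along the chain. The compounds shown leave open whether a longer chain or a fluorine on the terminal phenyl ring would move the number beyond the scatter. No measurement at hand explains either step.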